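The source may hold more compounds than are shown below. What is called first, only, known or untested is meant among the compounds shown, and "the series" means these compounds.

This account follows the step from compound 1 `Cc1ccc2c(c1)OCC(CN1CCC(n3c(O)nc4cc(C)ccc43)CC1)O2` to compound 3 `Cc1ccc2c(c1)nc(O)n2C1CCN(CC2COc3ccccc3O2)CC1` in a functional assay on the whole organism with Rattus norvegicus as the target; a higher number here means that more compound is needed for the effect, a lower number that less compound is needed. Of the compounds shown here, two have been measured so far. Compound 1 gives 6 mg/kg in this assay, the lower of the two numbers. Compound 2 `Oc1nc2cc(F)ccc2n1C1CCN(CC2COc3ccc(F)cc3O2)CC1` gives 20 mg/kg in this assay, a higher number, and the gap between compound 2 and compound 1 lies beyond the usual scatter. Compound 3 differs from compound 1 in one place: hydrogen in place of methyl on an aromatic carbon. For the measured compounds named here, no pair of measured compounds differs in only one place, so the effect of a single change of this kind has not been observed here. The change removes a single carbon and is modest in size. The step of a 1.3-fold higher number from compound 1 to compound 3 (0.12 log units; within the scatter) is expected to be small, toward a somewhat higher number, and not clearly beyond the scatter. Compound 3 is expected to give 8 mg/kg in this assay, with a range from 3 mg/kg to 20 mg/kg.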

Compound 3, dose for half-maximal effect: 40 mg/kg
For compound 3 the middle estimate is 5.0-fold (0.70 log units) below the measured one; measured number outside the range, above it.
By their numbers in this assay, from the lowest: compound 1; then compounds 2 and 3 (each within the scatter of the next).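

In this assay, hydrogen in place of methyl on this aromatic carbon gives a 6.7-fold higher number from compound 1 to compound 3 (0.82 log units; beyond the scatter). For the compounds shown here, this is the first single-place step available here, and it shows that the position is not indifferent to this change: the loss of one carbon from a six-membered aromatic ring of carbon only, part of a fused system of two rings, is enough to move the number beyond the scatter. Nothing at hand bears on why the step takes this size.

Still open, going by these compounds, is whether methyl is special at this carbon or whether a chlorine atom, a methoxy group or an ethyl group would serve equally well. Also open, on these data alone, is how much the other methyl, which compound 3 keeps, contributes to the number in this assay.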